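Fluoro for chloro on the shared core of compound 2

The source may hold more compounds than are shown below. What is called first, only, known or untested is meant among the compounds shown, and "the series" means these compounds.

Measured so far:
compound 1, `C=CC(=O)Nc1cccc(Nc2nc(Nc3ccc(OCCn4ccnc4)cc3)ncc2F)c1`, gives 8370 nM
compound 2, `C=CC(=O)Nc1cccc(Nc2nc(Nc3ccc(Cn4ccnc4)cc3)ncc2Cl)c1`, gives 2730 nM

Both numbers come from a functional assay on A549 cells (Homo sapiens) for antiproliferative activity, read by MTT assay, with a stated time of 48 h; on this read-out higher numbers stand for weaker inhibition and lower numbers for stronger inhibition. Compound 2 stands at the lowest of the two numbers shown; its nearest neighbour is compound 1, whose number is higher by a gap that lies beyond the usual scatter. For the measured compounds named here, no single-point step between the two measured compounds exists, since compound 1 and compound 2 differ in more than one place, so their two values show only that compound 2 inhibits more strongly than compound 1 in this assay.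

Compound 3, `C=CC(=O)Nc1cccc(Nc2nc(Nc3ccc(Cn4ccnc4)cc3)ncc2F)c1`, takes one step away from compound 2: fluoro in place of chloro on an aromatic carbon. Nothing in the measured pair isolates this exchange, so the size of its effect is open. He expects a modest shift toward a higher number, of a size that may or may not clear the scatter, because compound 1, the only fluoro-bearing compound measured, gives 8370 nM. He therefore estimates for compound 3 a value of 4500 nM, within a range of 1500 nM to 13000 nM. That estimate means a step of a 1.6-fold higher number from compound 2 to compound 3 (0.22 log units; within the scatter) in this assay.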

Compound 3, half-maximal inhibitory concentration: 3560 nM
For compound 3 the middle estimate is 1.3-fold (0.10 log units) above the measured one; the range from low to high includes it.
By their numbers in this assay, from the lowest: compounds 2 and 3 (each within the scatter of the next); then compound 1.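

Fluoro in place of chloro, on an aromatic carbon two atoms from the ring nitrogen, amounts in this assay to a 1.3-fold higher number from compound 2 to compound 3 (0.12 log units; within the scatter), so with the (1H-imidazol-1-yl)methyl group in place, this assay does not tell the two halogens apart at this position. Compound 3 also isolates the side chain, which the earlier pair could not do: (1H-imidazol-1-yl)methyl in place of 2-(1H-imidazol-1-yl)ethoxy gives a 2.4-fold lower number from compound 1 to compound 3 (0.37 log units; beyond the scatter), and of the two steps now readable, only this modest one clears the scatter. No measurement shown here offers an explanation for either step.

As far as these compounds go, the halogen exchange has been read with a single side chain and covers only fluoro and chloro, so it remains open how a bromo, methyl or nitrile group would read at this position. The side chain has likewise been sampled only twice, leaving open what a longer chain ending in the imidazole, or a dimethylamino or morpholine group in place of the imidazole, would give in this assay.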